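Urea series: ring-nitrogen-adjacent substituent swap, ether to thioether

The source may hold more compounds than are shown below. What is called first, only, known or untested is meant among the compounds shown, and "the series" means these compounds.

Measured compounds in an assay on CHO cells for agonist activity at transient receptor potential cation channel subfamily V member 1 (Homo sapiens); on this read-out lower numbers stand for an effect already at smaller amounts and higher numbers for an effect only at larger amounts of compound:
compound 1 `CCCN(CCC)c1nc(C(F)(F)F)ccc1CNC(=O)Nc1cccc2c(=O)[nH]ccc12` gives 2.79 nM
compound 2 `O=C(NCc1ccc(C(F)(F)F)nc1OCC1CCCC1)Nc1cccc2c(=O)[nH]ccc12` gives 15.5 nM

Among the compounds with values here, compound 2 stands with the higher of the two numbers; the only measured step, a 5.6-fold higher number from compound 1 to compound 2 (0.74 log units; beyond the scatter), lies beyond the scatter and separates it from compound 1.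

Compound 3 `O=C(NCc1ccc(C(F)(F)F)nc1SC1CCCCC1)Nc1cccc2c(=O)[nH]ccc12` is unmeasured. It differs from compound 2 in one place: cyclohexylsulfanyl in place of cyclopentylmethoxy on an aromatic carbon.

Within the data shown here, no measured step covers an oxygen-to-sulfur exchange or a five- to six-membered ring exchange. Among the measured compounds shown here, the one step on record, a 5.6-fold higher number from compound 1 to compound 2 (0.74 log units; beyond the scatter), shows that the group at this position on the shared core can shift this assay by a modest amount when a dipropylamino is replaced by a cyclopentylmethoxy. The change to compound 3 keeps the same atom count and a single acceptor, so a smaller shift than that step is expected, and its direction cannot be read from the data; a number near that of compound 2 or somewhat higher is expected.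

Compound 3 is therefore expected to give about 20 nM in this assay, between 7 nM and 60 nM, meaning a step of a 1.3-fold higher number from compound 2 to compound 3 (0.11 log units; within the scatter) that is expected to stay within the scatter.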

Compound 3, half-maximal effective concentration: 69.3 nM
Compound 3: middle estimate off by 3.5-fold (0.54 log units), on the low side, and the stated range ends below it.
By their numbers in this assay, from the lowest: compound 1; then compound 2; then compound 3.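

In this assay, the group on this aromatic carbon is not interchangeable even when heavy-atom and hydrogen-bond acceptor counts are matched: cyclohexylsulfanyl in place of cyclopentylmethoxy gives a 4.5-fold higher number from compound 2 to compound 3 (0.65 log units; beyond the scatter), a step of the same modest class as the earlier one. With compound 3 included, the three groups form a wider range at this one position, a 25-fold higher number from compound 1 to compound 3 (1.40 log units; beyond the scatter), and dipropylamino, in compound 1, gives the lowest number of the three. Nothing on record accounts for either new step.

The step from compound 2 to compound 3 changes the linking atom and the ring together, so the compounds shown do not divide it between oxygen-to-sulfur exchange and the change from cyclopentylmethyl to cyclohexyl; cyclohexyloxy or cyclopentylsulfanyl on the shared core would separate the two. Also open, on these data alone, is whether the lower number of compound 1 belongs to amines at this position more generally, which cyclohexylamino or piperidin-1-yl would test against the ether and the thioether.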